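Chain-end variation in a cinnamanilide series: lipophilicity notes

The source may hold more compounds than are shown below. What is called first, only, known or untested is meant among the compounds shown, and "the series" means these compounds.

Measured so far:
compound 1, `COc1cc(/C=C/C(=O)Nc2ccccc2)ccc1OCCCCN1CCCC1`, 1.6
compound 2, `CCN(CC)CCCCCCCCOc1ccc(/C=C/C(=O)Nc2ccccc2)cc1OC`, 1.75

Two compounds have been run in a physicochemical assay for lipophilicity, using the shake flask method, measured as octanol-water partition, at pH 7.4; a higher number here means a more lipophilic compound, a lower number a more polar compound. Compound 1 `COc1cc(/C=C/C(=O)Nc2ccccc2)ccc1OCCCCN1CCCC1` gives 1.6 in this assay, and compound 2 `CCN(CC)CCCCCCCCOc1ccc(/C=C/C(=O)Nc2ccccc2)cc1OC` gives 1.75. Among the compounds with values here, the one step between them, a number 0.15 log units higher from compound 1 to compound 2 (within the scatter), is small and within the scatter. Compound 2 thus stands highest of the two numbers, but only nominally, with compound 1 within the scatter of it.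

The next compound, compound 3 `COc1cc(/C=C/C(=O)Nc2ccccc2)ccc1OCCCCCCCCCCN(C)C`, keeps every atom of compound 2 and rearranges them: 2-(dimethylamino)ethyl in place of diethylamino on a saturated chain carbon, eight bonds along the chain from an oxygen on an aromatic ring. Within the data shown here, the only measured step that bears on this change is the one from compound 1 to compound 2, which also altered a diethylamino-bearing end of the chain and stayed within the scatter. With identical atom counts and no change in donors or acceptors, no step beyond the scatter is expected in this assay; the expected step of a number 0.05 log units higher from compound 2 to compound 3 (within the scatter) is essentially flat. Compound 3 is therefore estimated at 1.8, with a range from 1.4 to 2.2.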

Compound 3, partition coefficient: 1.8
Compound 3: middle estimate and measured number agree at the digits printed; the range from low to high includes it.
By their numbers in this assay, from the lowest: compounds 1, 2 and 3 (each within the scatter of the next).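

In this assay, 2-(dimethylamino)ethyl in place of diethylamino on a saturated chain carbon, eight bonds along the chain from an oxygen on an aromatic ring, gives a number 0.05 log units higher from compound 2 to compound 3 (within the scatter) and so leaves the two compounds unseparated, although the same atoms are joined differently. The larger replacement, 6-(dimethylamino)hexyl in place of pyrrolidin-1-yl on a saturated chain carbon, four bonds along the chain from an oxygen on an aromatic ring, gives a number 0.20 log units higher from compound 1 to compound 3 (within the scatter) and also stays unresolved, so the pyrrolidine-capped compound and both open-chain amines cannot be told apart in this assay on the present numbers. Nothing available accounts for this flat picture.

The compounds shown leave open whether a chain ending in a morpholine ring, a primary amine or a carboxylic acid would stay equally close to this group. They also leave open whether a much shorter or a longer chain, with the core of compound 1 unchanged, would give a step beyond the scatter.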